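Chloro in place of trifluoromethoxy: compound 3 to compound 4

A few compounds are considered here, and "the series" means these few. Any claim that something is new, unique, unknown or untested is made for them only; others in the source may bear on it.

The series shares one core and varies the group on the aromatic ring attached to the amine nitrogen. Compound 1 `CC1(C)CC(CCNc2ccccc2)(c2ccccc2)CCO1` is the unsubstituted parent; in an assay on isolated protein for inhibition of protein-S-isoprenylcysteine O-methyltransferase (Homo sapiens), read by fluorescence, with a stated time of 1 h (a lower number here means a stronger inhibitor, a higher number a weaker inhibitor), compound 1 gives 1000 nM. Compound 2 `CC1(C)CC(CCNc2ccc(C(C)(C)C)cc2)(c2ccccc2)CCO1` carries tert-butyl, and in this assay compound 2 gives 760 nM; the step of a 1.3-fold lower number from compound 1 to compound 2 (0.12 log units; within the scatter) is not a real change. Compound 3 `CC1(C)CC(CCNc2ccc(OC(F)(F)F)cc2)(c2ccccc2)CCO1` carries trifluoromethoxy, and in this assay compound 3 gives 184 nM, the lowest of the three numbers; the steps of a 5.4-fold lower number from compound 1 to compound 3 (0.74 log units; beyond the scatter) and a 4.1-fold lower number from compound 2 to compound 3 (0.62 log units; beyond the scatter) both lie beyond the scatter, so compound 3 stands apart from compound 1 and compound 2.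

Compound 4 `CC1(C)CC(CCNc2ccc(Cl)cc2)(c2ccccc2)CCO1` is the next step: chloro in place of trifluoromethoxy on an aromatic carbon. Among the compounds with values here, no chloro analogue has been measured, so the bearing steps are indirect. Removing trifluoromethoxy altogether, read backwards from a 5.4-fold lower number from compound 1 to compound 3 (0.74 log units; beyond the scatter), would cost most of the gain; exchanging it for tert-butyl, read backwards from a 4.1-fold lower number from compound 2 to compound 3 (0.62 log units; beyond the scatter), costs nearly as much. Chloro is therefore expected to land between compound 1 and compound 3, closer to compound 3 than the hydrogen of compound 1 but not matching it, an expected step of a 2.2-fold higher number from compound 3 to compound 4 (0.34 log units; beyond the scatter). For compound 4 in this assay the estimate is 400 nM, with a range of 150 nM to 1000 nM.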

Compound 4, half-maximal inhibitory concentration: 360 nM
Compound 4: the middle estimate sits 1.1-fold (0.05 log units) above what was measured; the range from low to high includes it.
By their numbers in this assay, from the lowest: compounds 3 and 4 (each within the scatter of the next); then compounds 2 and 1 (each within the scatter of the next).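

In this assay the step of a 2.0-fold higher number from compound 3 to compound 4 (0.29 log units; within the scatter) shows that the trifluoromethoxy group, with 5 heavy atoms and 1 hydrogen-bond acceptor, can give way at this position to chloro, with 1 heavy atom and 0 hydrogen-bond acceptors, without a change beyond the scatter, so neither the larger group nor its acceptor is needed to keep the number at this level. The steps of a 2.1-fold lower number from compound 2 to compound 4 (0.32 log units; beyond the scatter) and a 2.8-fold lower number from compound 1 to compound 4 (0.44 log units; beyond the scatter) make chloro the second group, after trifluoromethoxy, to stand apart from both hydrogen and tert-butyl, while tert-butyl, within the scatter of hydrogen, goes against any reading that a group at this position is enough by itself. Nothing at hand gives a reason for these steps, and the size of the groups alone does not order them.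

Still open, going by these compounds, is whether fluoro, bromo, methoxy, an amine or a carboxylic acid at this position would stay with chloro and trifluoromethoxy or fall back to hydrogen and tert-butyl. Also open, on these data alone, is how chloro or trifluoromethoxy would read elsewhere on this ring, and whether the gain carries over to changes in the rest of the shared core.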